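Methoxy to fluoro on an inactive sulfonamide-free core

The source may hold more compounds than are shown below. What is called first, only, known or untested is meant among the compounds shown, and "the series" means these compounds.

Compound 1 `COc1ccc(N2C(=O)COc3ccc(-c4cnc(Cl)c(NS(=O)(=O)c5ccc(F)cc5)c4)cc32)cc1` is tested in a functional assay on HepG2 cells (Homo sapiens) for antiproliferative activity, read by MTT assay, with a stated time of 72 h; on this read-out lower numbers stand for stronger inhibition and higher numbers for weaker inhibition. In this assay compound 1 reaches only the limit of the assay, > 40000 nM. Compound 2 `O=C1COc2ccc(-c3cnc(Cl)c(NS(=O)(=O)c4ccc(F)cc4)c3)cc2N1c1ccc(F)cc1` carries the change (fluoro in place of methoxy on an aromatic carbon). In this assay compound 2 likewise gives only a limit, > 40000 nM. The step that the two limits leave unreadable from compound 1 to compound 2 therefore cannot be read, because of the limit of > 40000 nM in this assay, at which 3 of the 3 values shown sit.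

Compound 3 `COc1ccc(N2C(=O)COc3ccc(-c4cnc5ccccc5c4)cc32)cc1` has a different core; the difference between the two cores is not broken down here. In this assay compound 3 again reaches only a limit, > 40000 nM. Compound 4 `O=C1COc2ccc(-c3cnc4ccccc4c3)cc2N1c1ccc(F)cc1` is the compound not yet measured, and it arises from compound 3 by the same change, (fluoro in place of methoxy on an aromatic carbon).

Since the three values that are known all sit at the limit, the step that the limit leaves unreadable from compound 3 to compound 4 is expected to be unreadable in the same way. Compound 4 is estimated to give 60000 nM in this assay, with a range from 20000 nM to 200000 nM, and most likely to be reported as a limit again.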

Compound 4, half-maximal inhibitory concentration: 37200 nM
Compound 4: the middle estimate sits 1.6-fold (0.21 log units) above what was measured, and the stated range covers the measured number.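

In this assay the change from 4-methoxyphenyl to 4-fluorophenyl gives an at least 1.0-fold lower number from compound 3 to compound 4 (0.03 log units; that floor lies within the scatter), and compound 4 is the only one of the four compounds shown with a value that is a number rather than a limit. For the compounds shown here, that floor does not fix the size of the step, which may be as small as the scatter or considerably larger, so the result shows only that the change on this core ends in a readable number. It does not show that the change carries from one core to the other, because neither step has a readable size and the step on the other core, between compound 1 and compound 2, cannot be read at all: the limit of > 40000 nM in this assay, at which 3 of the 4 values shown sit.

The compounds shown leave open how an amine or a carboxylic acid on that same aromatic carbon would read in this assay. They also leave open whether the 4-fluorophenyl group gives a readable number on any core other than that of compound 4.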